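Notes on an amide-for-amine exchange in the series

The source may report more compounds than this note shows. Statements on the series, on what has been measured and on what is new or still open speak of the compounds shown alone.

Three compounds in the series have numbers in an assay on HEK293 cells for displacement of a labelled ligand from Melanocortin receptor 4 (Homo sapiens); on this read-out higher numbers stand for weaker inhibition and lower numbers for stronger inhibition. Compound 1 `CCC(C)[C@H](N)c1cc(C(F)(F)F)ccc1N1CCN(C(=O)CCc2ccc(Cl)cc2)CC1` gives 86 nM, compound 2 `CC(C)C[C@H](N)c1cc(C(F)(F)F)ccc1N1CCN(C(=O)CCc2ccccc2O)CC1` gives 3300 nM, and compound 3 `CCC(C)[C@H](NC[C@H](C)N)c1cc(C(F)(F)F)ccc1N1CCN(C(=O)CCc2ccc(Cl)cc2Cl)CC1` gives 89 nM. Compound 3 thus stands second highest of the three, within the scatter of compound 1 and well apart from compound 2. Compound 4 `CC(C)C[C@H](NC(=O)CN)c1cc(C(F)(F)F)ccc1N1CCN(C(=O)CCc2ccc(Cl)cc2Cl)CC1` is not yet measured. It differs from compound 3 in one place: 1-(((aminomethyl)carbonyl)amino)-3-methylbutyl in place of 1-((2-aminopropyl)amino)-2-methylbutyl on an aromatic carbon. For the measured compounds named here, no pair of measured compounds differs in only one place, so no step isolating this change is known, and compound 2 differs from compounds 1 and 3 in more than one place, so its high number cannot be tied to a single change. A modest rise in the number, slightly beyond the scatter, is expected for a 3.4-fold higher number from compound 3 to compound 4 (0.53 log units; beyond the scatter). Compound 4 is estimated at 300 nM, between 60 nM and 1500 nM.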

Compound 4, inhibition constant: 19 nM
Beside the measured number, compound 4's estimate is 16-fold (1.20 log units) above it; the whole stated range lies above it.
By their numbers in this assay, from the lowest: compound 4; then compounds 1 and 3 (each within the scatter of the next); then compound 2.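

In this assay, for the compounds shown here, this aromatic carbon accepts the amide-bearing 1-(((aminomethyl)carbonyl)amino)-3-methylbutyl in place of 1-((2-aminopropyl)amino)-2-methylbutyl, with a 4.7-fold lower number from compound 3 to compound 4 (0.67 log units; beyond the scatter), the only step here that isolates one place. The two groups have equal counts of heavy atoms, donors and acceptors, so those counts do not separate them. No measured evidence accounts for the step.

The exchange also moves the methyl branch, so the compounds shown leave open whether the carbonyl or the branch position matters. Also open, from the compounds shown here alone, is how a longer aminoalkyl chain or a carboxylic acid would read here.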